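A few compounds are considered here, and "the series" means these few. Any claim that something is new, unique, unknown or untested is made for them only; others in the source may bear on it.

Measured in a functional assay on A549 cells (Homo sapiens) for antiproliferative activity, read by MTT assay, with a stated time of 48 h; on this read-out higher numbers stand for weaker inhibition and lower numbers for stronger inhibition:

- compound 1 `COc1ccc(-c2nc3cccc(-c4cc(OC)c(OC)c(OC)c4)c3o2)cc1OC` gives 2800 nM
- compound 2 `COc1ccc(-c2nc3cccc(-c4cc(OC)c(OC)c(OC)c4)c3o2)cc1F` gives 1800 nM
- compound 3 `COc1cc(-c2cccc3nc(-c4cccc(F)c4)oc23)cc(OC)c1OC` gives 2600 nM

Compound 3 stands at 2600 nM, and these numbers cannot separate it from the other two compounds. Its two neighbouring steps, a 1.1-fold lower number from compound 1 to compound 3 (0.03 log units; within the scatter) and a 1.4-fold higher number from compound 2 to compound 3 (0.16 log units; within the scatter), are both within the scatter.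

The next compound to be tested is compound 4 `COc1cc(-c2cccc3nc(-c4cccc(C)c4)oc23)cc(OC)c1OC`, which has methyl in place of fluoro on an aromatic carbon. Among the compounds with values here, no measured step makes this exact swap, so the evidence is indirect. The three measured steps all alter substituents on the same aromatic group, which makes them the closest available guide. Fluoro in place of methoxy gave a 1.6-fold lower number from compound 1 to compound 2 (0.19 log units; within the scatter), and 3-fluorophenyl in place of 3,4-dimethoxyphenyl gave a 1.1-fold lower number from compound 1 to compound 3 (0.03 log units; within the scatter). Hydrogen in place of methoxy gave a 1.4-fold higher number from compound 2 to compound 3 (0.16 log units; within the scatter). Within the data shown here, none of the three moved the number beyond the scatter, and no compound here goes against that pattern. A similarly small result is therefore expected, with no favoured direction. The expected step is a 1.0-fold lower number from compound 3 to compound 4 (0.02 log units; within the scatter), which would not stand out from the scatter.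

The estimated value for compound 4 is 2500 nM, with an expected range from 1100 nM to 5500 nM.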

Compound 4, half-maximal inhibitory concentration: 16700 nM
The estimate for compound 4 lay 6.7-fold (0.82 log units) below the measured number, and the stated range ends below it.
By their numbers in this assay, from the lowest: compounds 2, 3 and 1 (each within the scatter of the next); then compound 4.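

In this assay, within the data shown here, fluoro and methyl each contribute one heavy atom and neither counts any hydrogen-bond donors or acceptors, yet exchanging them gives a 6.4-fold higher number from compound 3 to compound 4 (0.81 log units; beyond the scatter) and shows that this position, on an aromatic carbon meta to a large group, is sensitive to what sits on it, something the earlier steps, all within the scatter, did not reveal. Compound 4 also separates from the two dimethoxy- and methoxy-bearing compounds, with a 9.3-fold higher number from compound 2 to compound 4 (0.97 log units; beyond the scatter) and a 6.0-fold higher number from compound 1 to compound 4 (0.78 log units; beyond the scatter), which makes it the weakest of the four, while the 3-fluorophenyl, 3-fluoro-4-methoxyphenyl and 3,4-dimethoxyphenyl compounds remain together within the scatter. No measurement shown offers an explanation for this gap.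

On these data alone, with only fluoro and methyl to compare directly at this position, it remains open whether a chlorine, a hydroxyl, an amine or a longer chain such as ethyl would behave like compound 3 or like compound 4. As far as these compounds go, it is also open whether methyl would give a step of similar size on the aryl group of compound 2, where a methoxy group shares the ring.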